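Swapping 3,4-dichlorophenyl for 4-cyanophenyl on a shared core

A few compounds are considered here, and "the series" means these few. Any claim that something is new, unique, unknown or untested is made for them only; others in the source may bear on it.

Three compounds sharing one core have entries in an ADME assay on Vero cells (Chlorocebus sabaeus) for cytotoxicity, read by MTT assay, with a stated time of 72 h; on this read-out lower numbers stand for higher toxicity in this test and higher numbers for lower toxicity in this test. For compound 1 `CN(C)c1ccc(/C=C/C(=O)c2ccc3c(c2O)C=CC(C)(C)O3)cc1` the entry is > 400000 nM, which is a limit of the assay and not a number. For compound 2 `CC1(C)C=Cc2c(ccc(C(=O)/C=C/c3ccc(Br)cc3)c2O)O1` the entry reads "not determined" (no result reported). Among the measured compounds shown here, compound 3 `CC1(C)C=Cc2c(ccc(C(=O)/C=C/c3ccc(Cl)c(Cl)c3)c2O)O1` gives 142000 nM, the only actual number in the set, so it is the single firm reference point.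

Compound 4 `CC1(C)C=Cc2c(ccc(C(=O)/C=C/c3ccc(C#N)cc3)c2O)O1` has 4-cyanophenyl in place of the 3,4-dichlorophenyl of compound 3, on a double-bonded chain carbon bound to a double-bonded chain carbon (4-cyanophenyl in place of 3,4-dichlorophenyl on a double-bonded chain carbon bound to a double-bonded chain carbon). For the measured compounds named here, no step between measured compounds exists to calibrate this change in this assay, so the expectation rests on compound 3 at 142000 nM alone. A modest move towards higher numbers is expected, and the estimated step is a 1.3-fold higher number from compound 3 to compound 4 (0.10 log units; within the scatter), which is hardly beyond the usual scatter. Compound 4 is expected at 180000 nM, with an estimated range of 70000 nM to 400000 nM.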

Compound 4, half-maximal cytotoxic concentration: 80200 nM
For compound 4 the middle estimate is 2.2-fold (0.35 log units) above the measured one, within the range that was stated.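

In this assay, 4-cyanophenyl in place of 3,4-dichlorophenyl gives a 1.8-fold lower number from compound 3 to compound 4 (0.25 log units; within the scatter), so these two groups cannot be told apart at this position. Cyano in place of dimethylamino on an aromatic carbon is the first change in the set to go beyond the scatter, with an at least 4.9-fold lower number from compound 1 to compound 4 (0.69 log units; beyond the scatter). The full size of that step stays unknown because compound 1 stands at a limit of the assay and not at a number: the limit of > 400000 nM in this assay, at which 1 of the 4 values shown sits.

Compound 2 has no result, so it adds no comparison in this assay. From the compounds shown here alone, how a carboxylic acid or a simple primary amine on that aromatic carbon would read remains open, as does whether the cyano and dimethylamino step would hold on any other core.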